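A Charged Chain Swap on a Weak Binder

The source may hold more compounds than are shown below. What is called first, only, known or untested is meant among the compounds shown, and "the series" means these compounds.

Of the compounds shown here, three have been measured in an assay for displacement of a labelled ligand from protein arginine N-methyltransferase 1 (Homo sapiens), read by scintillation proximity assay, with stated times of 5 min and 8 min, tested at 10 uM; on this read-out higher numbers stand for a stronger effect at the one concentration tested and lower numbers for a weaker effect. Compound 1 `CN1/C(=C/C=C/C2=[N+](CCC[N+](C)(C)C)c3ccccc3C2(C)C)C(C)(C)c2ccccc21` gives 2%, the lowest of the three numbers. Compound 2 `CCCC[N+]1=C(/C=C/C=C2/N(C)c3ccccc3C2(C)C)C(C)(C)c2cc(Br)ccc21` gives 36%, and compound 3 `C(/C=C/c1sc2ccccc2[n+]1CCCc1ccccc1)=C1/Sc2ccccc2N1CCCc1ccccc1` gives 76%; both sit above compound 1 by more than the usual scatter, compound 3 by the widest margin. No two of the measured compounds differ in only one place, so no single step can be read off from them.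

Compound 4 `CN1/C(=C/C=C/C2=[N+](CCCS(=O)(=O)[O-])c3ccccc3C2(C)C)C(C)(C)c2ccccc21` has not yet been measured. It differs from compound 1 by a group of 4 heavy atoms (3 oxygen, 1 sulfur; no ring) in place of a group of 4 heavy atoms (3 carbon, 1 nitrogen; no ring), on a saturated chain carbon, three bonds along the chain from a double-bonded nitrogen in a ring. Nothing measured shows what such a swap does in this assay, since compound 2 and compound 3 each differ from compound 1 in several parts at once. Within the data shown here, because compound 1 gives 2%, there is little room for a fall, and no measured step points toward a rise. The step from compound 1 to compound 4 is expected to be small, a number 3 percentage points higher from compound 1 to compound 4 (within the scatter), not beyond the scatter. Compound 4 is therefore estimated at 5%, within a range from -10% to 25%.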

Compound 4, a percentage reported as inhibition, at one concentration (the size of the read-out at that concentration, not a potency): "not active" (no number reported)
No number was reported for compound 4; there is nothing to compare the estimate with.
By their numbers in this assay, from the lowest: compound 1; then compound 2; then compound 3.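

Among these compounds, compound 4 is reported only as not active, with no number, so no step from compound 1 to compound 4 can be read. No supporting data bear on this result. On these data alone, the effect of replacing the group of net charge +1 with the group of net charge -1 on the core of compound 1 remains open.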